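Fluoro substitution on the N-aryl ring of a pyrazoline series

The source may hold more compounds than are shown below. What is called first, only, known or untested is meant among the compounds shown, and "the series" means these compounds.

Measured so far:
compound 1 `CC(C)(C)C1=NN(c2cccc(Cl)c2)C(c2ccc(O)cc2)C1`: 5200 nM
compound 3 `CC(C)(C)C1=NN(c2ccc(F)c(Cl)c2)C(c2ccc(O)cc2)C1`: 900 nM
compound 2 `CC(C)(C)C1=NN(c2ccc(F)cc2F)C(c2ccc(O)cc2)C1`: "not determined" (no result reported)

In an assay on isolated protein for inhibition of protein kinase C zeta type (Homo sapiens), with a stated time of 4 min (a higher number here means a weaker inhibitor, a lower number a stronger inhibitor), compound 1 gives 5200 nM and compound 3 gives 900 nM. The change between them is fluoro in place of hydrogen on an aromatic carbon, and it gave a 5.8-fold lower number from compound 1 to compound 3 (0.76 log units; beyond the scatter). Compound 2 differs from compound 1 by 2,4-difluorophenyl in place of 3-chlorophenyl on an amine nitrogen in a ring; in this assay compound 2 gives "not determined" (no result reported), so no number exists for it. Compound 4 `CC(C)(C)C1=NN(c2ccc(F)c(F)c2F)C(c2ccc(O)cc2)C1` differs from compound 2 by fluoro in place of hydrogen on an aromatic carbon, the same kind of change as from compound 1 to compound 3, though the place differs: ortho to two fluoro groups and meta to a large group, rather than ortho to a chloro group and para to a large group. For compound 4 in this assay a step of similar size from compound 2 is expected, resting only on a 5.8-fold lower number from compound 1 to compound 3 (0.76 log units; beyond the scatter). With no number for compound 2, compound 4 is estimated at 2500 nM, between 500 nM and 12000 nM.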

Compound 4, half-maximal inhibitory concentration: 700 nM
Estimate against measurement, compound 4: 3.6-fold (0.55 log units) above; the range from low to high includes it.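

Within the data shown here, compound 2 has no number in this assay, and no step to compound 4 can be read from it. Going by these compounds, what the added fluoro alone contributes between compound 2 and compound 4 stays open. No measurement on hand offers an explanation for the value of compound 4.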